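The compounds below may be only part of what the source reports. "The series", "measured", "known", "first", "only" and "open" are said of these compounds alone.

Compound 1 `CCCCO/N=C/c1c(N)ncnc1Oc1ccc2[nH]c(C)cc2c1F` is one of three compounds sharing a common core that have been tested in a functional assay on HeLa cells (Homo sapiens) for antiproliferative activity; a lower number here means a stronger inhibitor, a higher number a weaker inhibitor. In that test compound 1 gives 607 nM, the highest of the three numbers. Compound 2 `Cc1cc2c(F)c(Oc3ncnc(N)c3/C=N/OCCO)ccc2[nH]1` gives 406 nM, and compound 3 `CCO/N=C/c1c(N)ncnc1Oc1ccc2[nH]c(C)cc2c1F` gives 32 nM. The step of a 1.5-fold lower number from compound 1 to compound 2 (0.17 log units; within the scatter) is small, whereas a 19-fold lower number from compound 1 to compound 3 (1.28 log units; beyond the scatter) and a 13-fold lower number from compound 2 to compound 3 (1.10 log units; beyond the scatter) are both large, so shortening the chain on the oxime oxygen mattered far more than adding a hydroxy to it.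

Compound 4 `COCCCO/N=C/c1c(N)ncnc1Oc1ccc2[nH]c(C)cc2c1F` has not yet been measured. It differs from compound 1 as follows: methoxy in place of methyl on a saturated chain carbon, three bonds along the chain from an oxygen on an unsaturated carbon. This lengthens the chain rather than shortening it, so the large gains seen for compound 3 do not apply; the closer comparison is compound 2, where adding an oxygen-bearing group left the number within the scatter. The expected step is therefore a 1.1-fold higher number from compound 1 to compound 4 (0.03 log units; within the scatter), none beyond the scatter. Compound 4 is estimated at 650 nM, with a likely range from 300 nM to 1500 nM.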

Compound 4, half-maximal inhibitory concentration: 346 nM
Beside the measured number, compound 4's estimate is 1.9-fold (0.27 log units) above it, and the stated range covers the measured number.
By their numbers in this assay, from the lowest: compound 3; then compounds 4, 2 and 1 (each within the scatter of the next).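

Replacing butyl with 3-methoxypropyl in this assay gives a change that stays within the scatter (a 1.8-fold lower number from compound 1 to compound 4 (0.24 log units; within the scatter)), so this longer chain carrying an added oxygen cannot be told apart from the plain butyl chain. It also cannot be told apart from the hydroxy-bearing chain of compound 2 (a 1.2-fold lower number from compound 2 to compound 4 (0.07 log units; within the scatter)), yet it remains clearly separate from the shorter chain of compound 3 (an 11-fold higher number from compound 3 to compound 4 (1.03 log units; beyond the scatter)). Among these four compounds, then, compound 3 alone stands apart, and no measurement is available to explain why.

Still open, as far as these compounds go, is whether a chain shorter than that of compound 3, such as a methyl on the same oxygen, would lower the number further. Also open, from the compounds shown here alone, is whether an amine at the end of the longer chain would behave like the methoxy and hydroxy groups.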